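This account rests on a few compounds, and the source may have more. Where it says the series, first, only, none or still open, it means among the compounds named here.

Measured so far in a functional assay on EL4 cells (Mus musculus) for inhibition, tested at 100 uM; on this read-out higher numbers stand for more inhibition at the one concentration tested (going by the name of the read-out) and lower numbers for less inhibition:
- compound 1 (`Sc1[nH]ccc2ncnc1-2`) gives < 5%
- compound 2 (`[O-][n+]1ccc2c(c1)ncn2C1O[C@H](CO)[C@@H](O)[C@H]1O`) gives < 5%

Where compound 1 stands: in this assay compound 1 returns only a limit of the assay, < 5%, not a number. Compound 2 likewise returns a limit, < 5%. Both readings meet at the limit of < 5% in this assay, at which 2 of the 2 values shown sit, so nothing within the measured set separates one compound from the other. Among the compounds with values here, no pair of measured compounds differs in a single place, and no measured step size is available.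

Compound 3 (`CSc1[nH]ccc2ncnc1-2`) differs from compound 1 in one place: methyl in place of hydrogen on a sulfur. The single added carbon on the sulfur gives no ground, from what is measured, to expect a move beyond the scatter. The expected step is a number no lower from compound 1 to compound 3 (the limit leaves the size open), of no certain direction and no larger than the scatter. For compound 3 the estimate in this assay is 5%, within 0% to 20%, most likely reported again only as a limit.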

Compound 3, a percentage reported as inhibition, at one concentration (the size of the read-out at that concentration, not a potency): < 5%
Compound 3 gave a limit, no number; the forecaster's own chance of this, stated with the estimate: 70%; the middle value lies on the limit itself.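

In this assay no step can be read between compound 1 and compound 3, as both return only a limit of the assay: the limit of < 5% in this assay, at which 3 of the 3 values shown sit.

The compounds shown leave open which change to the shared core, if any, would lift inhibition clear of that limit.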